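Swapping Chloro for Trifluoromethyl on the Urea Aryl Ring

The compounds below may be only part of what the source reports. "The series", "measured", "known", "first", "only" and "open" are said of these compounds alone.

Compound 1 `O=C(Nc1cccc(-n2cc(-c3ccncc3)c(-c3ccc(Cl)c(O)c3)n2)c1)Nc1ccc(Cl)c(Cl)c1`: 939 nM
Compound 2 `COc1cc(-c2nn(-c3cccc(NC(=O)Nc4cccc(C(F)(F)F)c4)c3)cc2-c2ccncc2)ccc1Cl`: 789 nM
Compound 3 `COc1cc(-c2nn(-c3cccc(NC(=O)c4ccccc4)c3)cc2-c2ccncc2)ccc1Cl`: 567 nM

In a functional assay on LOX IMVI cells (Homo sapiens) for inhibition, read by sulforhodamine B assay, with a stated time of 48 h (a higher number here means a weaker inhibitor of growth, a lower number a stronger inhibitor of growth), compound 1 gives a number that lies within the usual scatter of the numbers for compound 2 and compound 3, so none of the three can be ranked against the others. Compound 4 `O=C(Nc1cccc(-n2cc(-c3ccncc3)c(-c3ccc(Cl)c(O)c3)n2)c1)Nc1ccc(Cl)c(C(F)(F)F)c1` differs from compound 1 in a single place: trifluoromethyl in place of chloro on an aromatic carbon. Among the measured compounds shown here, no measured pair shares this change. For the measured compounds named here, the one available step, a 1.4-fold lower number from compound 2 to compound 3 (0.14 log units; within the scatter), touches a different part of the molecule and stays within the scatter, so it gives no direction here. Nothing in the data therefore points to a shift beyond the scatter, and compound 4 is expected to give about 900 nM, between 400 nM and 2000 nM. The implied step, a 1.0-fold lower number from compound 1 to compound 4 (0.02 log units; within the scatter), is expected to stay within the scatter.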

Compound 4, concentration for 50% growth inhibition: 554 nM
Compound 4: the middle estimate sits 1.6-fold (0.21 log units) above what was measured, and the stated range covers the measured number.
By their numbers in this assay, from the lowest: compounds 4, 3, 2 and 1 (each within the scatter of the next).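

In this assay, placing trifluoromethyl on this aromatic carbon, ortho to a chloro group, gives a 1.7-fold lower number from compound 1 to compound 4 (0.23 log units; within the scatter) and so leaves growth inhibition unchanged within the scatter. This carbon of the ring therefore accepts a group of four heavy atoms in place of a single chlorine with no readable change in the number. No measurement here bears on why the step is this small. From the compounds shown here alone, what a nitrile or an amine on this carbon would do remains open, as does whether this swap behaves the same way on a different core.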